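Demethylation of a Ring Amine, Carried onto a Second Core

The source may hold more compounds than are shown below. What is called first, only, known or untested is meant among the compounds shown, and "the series" means these compounds.

Of the compounds shown here, three have been measured in a physicochemical assay (Homo sapiens) for solubility, with a stated time of 18 h, at pH 7.4; on this read-out lower numbers stand for lower solubility and higher numbers for higher solubility. Compound 1 `CN1CCN(c2ccc(/C=C3/SC(Nc4ccc(O)cc4)=NC3=O)cc2)CC1` gives 0.01 ug/mL. Compound 2 `O=C1N=C(Nc2ccc(O)cc2)S/C1=C/c1ccc(N2CCNCC2)cc1` gives 13.9 ug/mL, and compound 3 `CN1CCN(c2ccc(/C=C3/SC(N(C)c4ccccc4)=NC3=O)cc2)CC1` gives 18.9 ug/mL. Compound 2 arises from compound 1 by the change (hydrogen in place of methyl on an amine nitrogen in a ring), and the step is a 1400-fold higher number from compound 1 to compound 2 (3.14 log units; beyond the scatter). Compound 3 also arises from compound 1, and that step is a 1900-fold higher number from compound 1 to compound 3 (3.28 log units; beyond the scatter). Compound 3 holds the highest of the three numbers, but its value and that of compound 2 lie within the scatter of each other, so no order between them can be stated.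

Compound 4 `CN(C1=NC(=O)/C(=C\c2ccc(N3CCNCC3)cc2)S1)c1ccccc1` has not yet been measured. It differs from compound 3 by hydrogen in place of methyl on an amine nitrogen in a ring, the same change that turned compound 1 into compound 2, made at a place described in identical words. The two cores on which the change is made differ by methyl(phenyl)amino in place of (4-hydroxyphenyl)amino on a carbon with a double bond to nitrogen. The earlier step was very large, but it began from the lowest number of the set, since compound 1 gives only 0.01 ug/mL, whereas compound 3 already sits among the higher values. The step expected from compound 3 to compound 4 in this assay is therefore estimated as a 1.9-fold higher number from compound 3 to compound 4 (0.27 log units; within the scatter), clearly smaller than the earlier one, because compound 3 starts from 18.9 ug/mL. Compound 4 is expected to give about 35 ug/mL. The estimated range for compound 4 runs from 10 ug/mL to 120 ug/mL.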

Compound 4, solubility: 3.89 ug/mL
Compound 4: the middle estimate sits 9.0-fold (0.95 log units) above what was measured; measured number outside the range, below it.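

In this assay, hydrogen in place of methyl on the ring amine nitrogen did not carry from one core to the other: the step was a 1400-fold higher number from compound 1 to compound 2 (3.14 log units; beyond the scatter) on the core of compound 1, whereas the same change gave a 4.9-fold lower number from compound 3 to compound 4 (0.69 log units; beyond the scatter) on the core of compound 3, in the opposite direction and beyond the scatter. The change between the cores also read differently with each ring amine, with a 1900-fold higher number from compound 1 to compound 3 (3.28 log units; beyond the scatter) when 4-methylpiperazin-1-yl was present and a 3.6-fold lower number from compound 2 to compound 4 (0.55 log units; beyond the scatter) when piperazin-1-yl was present, so across these four compounds the two changes do not add independently. This shows that both the direction and the size of the step depended on the core here, but one pair on each core does not show how the change would behave on a further core, and nothing at hand says why the direction reverses.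

The compounds shown leave open how an ethyl or acetyl group on that ring nitrogen would compare with methyl and hydrogen. They also leave open whether the hydroxyl or the methyl on the amino nitrogen governs the reversal, a question that a plain phenylamino group on the same core could separate.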